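This account rests on a few compounds, and the source may have more. Where it says the series, first, only, none or still open, it means among the compounds named here.

Compound 1 `Cc1nc(-c2ccc(Cl)cc2)sc1C(=O)CSc1nc(-c2ccc(Cl)c(Cl)c2)c(C#N)c(=O)[nH]1` gives 36.5% in a functional assay on U-87MG ATCC cells for antiproliferative activity against U-87 MG (Homo sapiens), read by MTT assay, with a stated time of 48 h, tested at 100 uM; on this read-out lower numbers stand for a stronger effect and higher numbers for a weaker effect at the one concentration tested; compound 2 `Cc1nc(-c2ccccc2)sc1C(=O)CSc1nc(-c2ccc(Cl)c(Cl)c2)c(C#N)c(=O)[nH]1` gives 24.4%; compound 3 `COc1ccc(-c2nc(C)c(C(=O)CSc3nc(-c4ccc(Cl)c(Cl)c4)c(C#N)c(=O)[nH]3)s2)cc1` gives 31.1%.

Compound 1 stands highest of the three, with compound 3 nearest, a number 5.4 percentage points lower from compound 1 to compound 3 (within the scatter), and compound 2 furthest, a number 12.1 percentage points lower from compound 1 to compound 2 (beyond the scatter). Compound 4 `Cc1nc(-c2ccc(Cl)cc2)sc1C(=O)CSc1nc(-c2ccc(Cl)cc2)c(C#N)c(=O)[nH]1` has not yet been measured. It differs from compound 1 in one place: hydrogen in place of chloro on an aromatic carbon. Going by the values given here, of the measured steps, only the one from compound 1 to compound 2 is the same kind of change, and there it reads a number 12.1 percentage points lower from compound 1 to compound 2 (beyond the scatter). Among the compounds with values here, since that is the lone precedent, a modest fall, smaller than the one to compound 2, is expected for compound 4, namely a number 7.5 percentage points lower from compound 1 to compound 4 (within the scatter). Compound 4 is therefore estimated at 29%, between 19% and 40%.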

Compound 4, a percentage reported as activity, at one concentration (the size of the read-out at that concentration, not a potency): 12.8%
Compound 4: the middle estimate sits 16.2 percentage points above what was measured; the whole stated range lies above it.
By their numbers in this assay, from the lowest: compound 4; then compounds 2, 3 and 1 (each within the scatter of the next, the first and the last beyond it).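

In this assay the change from 3,4-dichlorophenyl to 4-chlorophenyl reads a number 23.7 percentage points lower from compound 1 to compound 4 (beyond the scatter), so the chloro ortho to a chloro group is not needed for the effect at the one concentration tested. Going by these compounds alone, until now the only precedent for this kind of change was elsewhere in the molecule, a number 12.1 percentage points lower from compound 1 to compound 2 (beyond the scatter), and the fall is now seen at this second place as well. No measurement shown accounts for this fall.

Going by these compounds, it remains open whether an amine or a fluoro at this place would give a lower or a higher number than hydrogen. Also open, on these data alone, is what happens if the remaining chloro on this ring gives way to hydrogen.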